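The source may hold more compounds than are shown below. What is called first, only, known or untested is meant among the compounds shown, and "the series" means these compounds.

The series is built on the shared core of compound 1 `CNC(=O)c1cc(Oc2ccc(/C=C/C(=O)c3ccc([N+](=O)[O-])cc3)cc2)ccn1`, which in a functional assay on HepG2 cells (Homo sapiens) for cytotoxicity, read by MTT assay, with a stated time of 72 h (on this read-out lower numbers stand for stronger inhibition and higher numbers for weaker inhibition), gives 41400 nM. Compound 3 `CNC(=O)c1cc(Oc2ccc(/C=C/C(=O)c3ccc(Cl)cc3)cc2)ccn1` keeps that core and carries chloro in place of nitro on an aromatic carbon; in this assay compound 3 gives 36600 nM. Among the measured compounds shown here, the step of a 1.1-fold lower number from compound 1 to compound 3 (0.05 log units; within the scatter) is the only one measured between compounds that differ in one place, and it does not reach beyond the scatter.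

For the measured compounds named here, compound 2 `CNC(=O)c1cc(Oc2ccc(C(=O)/C=C/c3cccc([N+](=O)[O-])c3)cc2)ccn1` is measured only as a limit in this assay, > 50000 nM, and no number is known for it; it is the one compound that sits at the limit of > 50000 nM in this assay, at which 1 of the 3 values shown sits.

Compound 4 `CNC(=O)c1cc(Oc2ccc(C(=O)/C=C/c3cccc(Br)c3)cc2)ccn1` has not yet been measured in this assay. It differs from compound 2 in one place: bromo in place of nitro on an aromatic carbon. The closest measured guide is the exchange of nitro for a halogen seen from compound 1 to compound 3, which stayed within the scatter. On that basis compound 4 is expected to show a number no higher from compound 2 to compound 4 (the limit leaves the size open), that is no step beyond the scatter, and the measurement may again return only a limit. The estimate for compound 4 in this assay is 50000 nM, with a range from 25000 nM to 120000 nM.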

Compound 4, half-maximal inhibitory concentration: 2870 nM
Beside the measured number, compound 4's estimate is 17-fold (1.24 log units) above it; measured number below the stated range.
By their numbers in this assay, from the lowest: compound 4; then compounds 3 and 1 (each within the scatter of the next). At a limit, above all of these: compound 2.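

In this assay, among the compounds shown here, the exchange of 3-nitrophenyl for 3-bromophenyl gives an at least 17-fold lower number from compound 2 to compound 4 (1.24 log units; beyond the scatter), the first step that lies beyond the scatter. Compound 2 is held only as a limit, so this step has a lower bound and no fixed size: the limit of > 50000 nM in this assay, at which 1 of the 4 values shown sits. The earlier exchange of nitro for a halogen gave only a 1.1-fold lower number from compound 1 to compound 3 (0.05 log units; within the scatter), so replacing nitro with a halogen does not have one uniform outcome across the compounds shown, and that pair goes against any general rule drawn from compound 4.

The two steps differ in the halogen and in the compound that carries it, and the compounds shown do not separate these differences, so it remains open whether the larger step belongs to bromo itself or to its setting in compound 4. Also open, from the compounds shown here alone, is how an amine, a methoxy group or a carboxylic acid would compare with bromo on this aromatic carbon, and whether any such group would give a number near that of compound 4 in this assay.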